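Halogen swap on the aryl pyrazole: chloro to fluoro

The source may hold more compounds than are shown below. What is called first, only, known or untested is meant among the compounds shown, and "the series" means these compounds.

Measured compounds:
compound 1 `Cc1cc(Nc2ccn(Cc3cccc4ccccc34)n2)n2nc(SCc3ccc(Br)cc3)nc2n1`, 5660 nM
compound 2 `Cc1cc(Nc2cc(-c3ccc(Cl)cc3)[nH]n2)n2nc(SCc3ccc(Br)cc3)nc2n1`, 4920 nM
compound 3 `Cc1cc(Nc2cc(-c3ccccc3)[nH]n2)n2nc(SCc3ccc(C(F)(F)F)cc3)nc2n1`, 4240 nM

All three were run in a functional assay on PC-9 cells (Homo sapiens) for inhibition, read by MTT assay, with a stated time of 72 h; on this read-out higher numbers stand for weaker inhibition and lower numbers for stronger inhibition. In this assay compound 1 gives 5660 nM, compound 2 gives 4920 nM and compound 3 gives 4240 nM. The three numbers sit close together: compound 2 is within the scatter of compound 1 and also within the scatter of compound 3, so no ordering among them can be read from these data.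

Compound 4 `Cc1cc(Nc2cc(-c3ccc(F)cc3)[nH]n2)n2nc(SCc3ccc(Br)cc3)nc2n1` has not yet been measured. It differs from compound 2 in one place: fluoro in place of chloro on an aromatic carbon. Within the data shown here, no measured pair shows this change, so its effect is unknown here.

Given that compound 2 gives 4920 nM in this assay, the step from compound 2 to compound 4 is expected to be small, estimated as a 1.1-fold higher number from compound 2 to compound 4 (0.05 log units; within the scatter), with no direction beyond the scatter. Compound 4 is therefore expected to give about 5500 nM, within a range of 2500 nM to 12000 nM.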

Compound 4, half-maximal inhibitory concentration: 6210 nM
Compound 4: the middle estimate sits 1.1-fold (0.05 log units) below what was measured; the range from low to high includes it.
By their numbers in this assay, from the lowest: compounds 3, 2, 1 and 4 (each within the scatter of the next).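

The series now has its first comparison of compounds that differ in one place: in this assay the change reads a 1.3-fold higher number from compound 2 to compound 4 (0.10 log units; within the scatter) and stays within the scatter. At this aromatic carbon, para to a large group, 4-chlorophenyl and 4-fluorophenyl therefore cannot be told apart in this assay, so this halogen exchange gives no readable gain or loss. The finding rests on this single pair and covers only these two halogens, and no measurement shown bears on the reason for the size of this step.

Going by these compounds, whether a non-halogen group at this carbon, such as an amine, a carboxylic acid or a methoxy group, would move the number beyond the scatter remains open. Also open, on these data alone, is whether fluoro in place of chloro would read the same with another group in place of the bromobenzyl group on sulfur.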